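This account rests on a few compounds, and the source may have more. Where it says the series, first, only, none or still open, it means among the compounds named here.

Compound 1 `C=C1C(=O)OC[C@@H]1CCOC(=O)Nc1ccc(CCCC)cc1` — 9950 nM
Compound 2 `C=C1C(=O)OC[C@H]1CCOC(=O)Nc1ccc(CCCC)cc1` — 15900 nM

In an ADME assay on RAW264.7 cells (Mus musculus) for cytotoxicity, read by MTT assay, with a stated time of 18 h (on this read-out lower numbers stand for higher toxicity in this test and higher numbers for lower toxicity in this test), compound 1 holds the lower of the two numbers, and compound 2 sits a 1.6-fold higher number from compound 1 to compound 2 (0.20 log units; within the scatter); these two differ only by the fact that compounds 1 and 2 differ only in the configuration as drawn. Compound 3 `C=C1C(=O)OC[C@@H]1CCOC(=O)Nc1ccc(OC)cc1` keeps the shared core and brings (methoxy in place of butyl on an aromatic carbon). For the measured compounds named here, no measured step touches this position, since the single step recorded concerns configuration alone, so nothing here sets the size of the change. The expectation is therefore cautious: a 1.4-fold higher number from compound 1 to compound 3 (0.15 log units; within the scatter), with room on either side. Compound 3 is expected to give 14000 nM, within 5000 nM to 40000 nM.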

Compound 3, half-maximal cytotoxic concentration: 11900 nM
Beside the measured number, compound 3's estimate is 1.2-fold (0.07 log units) above it; the measured number falls inside the stated range.
By their numbers in this assay, from the lowest: compounds 1, 3 and 2 (each within the scatter of the next).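

For the compounds shown here, replacing butyl with methoxy on an aromatic carbon gives a 1.2-fold higher number from compound 1 to compound 3 (0.08 log units; within the scatter) in this assay, the first measured change at this position. Across this one swap, the number stays within the usual scatter, even though the group changes from all carbon to one holding an oxygen and a hydrogen-bond acceptor. Nothing known about these compounds gives a reason for this result. As far as these compounds go, whether an amine, a carboxylic acid or a longer chain at this position would also stay within the scatter remains open, and one swap cannot show how far this holds.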